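A Thiophene-Bearing Chain Gives Way to an Indane

The compounds below may be only part of what the source reports. "The series", "measured", "known", "first", "only" and "open" are said of these compounds alone.

Compound 1 `COc1cc([C@@H](O)[C@@H](CCCc2ccsc2)Cn2ccc(CC(=O)O)c2)cc(OC)c1C` was tested in an ADME assay on microsomes (Rattus norvegicus) for metabolic stability, using NADPH; a higher number here means that the compound lasts longer, a lower number that the compound disappears faster. In this assay compound 1 gives < 0.25 h, which is a limit of the assay rather than a measured number. Compound 2 `COc1cc([C@@H](O)[C@@H](CCCc2ccsc2)Cn2ccc(CCC(=O)O)c2)cc(OC)c1C` carries a carboxymethyl in place of carboxy on a saturated chain carbon bound to an aromatic carbon. In this assay compound 2 gives < 0.25 h, again a limit. Among the compounds with values here, the one measured step reads a step that the two limits leave unreadable from compound 1 to compound 2. Compound 1 thus stands at the floor of the assay, and the limit of < 0.25 h in this assay, at which 2 of the 2 values shown sit, is all the evidence available.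

Compound 3 `COc1cc([C@@H](O)[C@@H](CC2Cc3ccccc3C2)Cn2ccc(CC(=O)O)c2)cc(OC)c1C` differs from compound 1 in one place: 2,3-dihydro-1H-inden-2-yl in place of 2-(thiophen-3-yl)ethyl on a saturated chain carbon, three bonds along the chain from an aromatic carbon, an aromatic nitrogen and an oxygen on a saturated carbon. Within the data shown here, no measured step touches this change, and the only measured step, from compound 1 to compound 2, could not be read. Any expectation therefore rests on where compound 1 sits. Compound 3 is expected to remain near that floor, a step that the limit leaves unreadable from compound 1 to compound 3. The estimate for compound 3 in this assay is 0.2 h, ranging from 0.08 h to 0.6 h.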

Compound 3, half-life: 0.567 h
Beside the measured number, compound 3's estimate is 2.8-fold (0.45 log units) below it; the measured number falls inside the stated range.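

This position on the saturated chain carbon responds to change: with 2,3-dihydro-1H-inden-2-yl in place of 2-(thiophen-3-yl)ethyl, this assay shows an at least 2.2-fold higher number from compound 1 to compound 3 (0.35 log units; beyond the scatter). Compound 3 is therefore the only compound shown that gives a measured number rather than a limit, whereas the step from compound 1 to compound 2 cannot be read. The real size of the new step remains unknown, since it starts from a limit: the limit of < 0.25 h in this assay, at which 2 of the 3 values shown sit.

The compounds shown leave open whether the gain needs the closed ring of 2,3-dihydro-1H-inden-2-yl, or whether an open 3-phenylpropyl chain in the same place would serve as well. They also leave open how the carboxymethyl change seen in compound 2 would read on the core of compound 3.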